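The source may report more compounds than this note shows. Statements on the series, on what has been measured and on what is new or still open speak of the compounds shown alone.

In a physicochemical assay for lipophilicity, using the shake flask method, in phosphate buffer, with a stated time of 1 h (a higher number here means a more lipophilic compound, a lower number a more polar compound), three compounds sharing one core have been measured. Compound 3 `CCCCCC(=O)OC[C@H]1O[C@@H](n2cnc3c(N)ncnc32)[C@@H](O)[C@@H]1O` gives 1.78 and compound 2 `Nc1ncnc2c1ncn2[C@@H]1O[C@H](COC(=O)CCc2ccccc2)[C@@H](O)[C@@H]1O` gives 1.73. These two values stand level, as a number 0.05 log units higher from compound 2 to compound 3 (within the scatter) shows. Compound 1 `CCCCCCCC(=O)OC[C@H]1O[C@@H](n2cnc3c(N)ncnc32)[C@@H](O)[C@@H]1O` reads >= 2, which is a limit and not a number.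

Compound 4 `CCCC(=O)OC[C@H]1O[C@@H](n2cnc3c(N)ncnc32)[C@@H](O)[C@@H]1O` has not yet been measured. It differs from compound 3 by hydrogen in place of ethyl on a saturated chain carbon, three bonds along the chain from a carbonyl carbon, with hydrogen in place of ethyl on a saturated chain carbon, three bonds along the chain from a carbonyl carbon. Among the measured compounds shown here, the closest precedent is the same exchange made five bonds along the chain, a number at least 0.22 log units lower from compound 1 to compound 3 (that floor lies within the scatter). That step gives only a floor, and the floor lies within the scatter, so it points in a direction without fixing a size. In this assay, a fall beyond the scatter is nevertheless expected, although its size remains a judgement. The expected change is a number 0.88 log units lower from compound 3 to compound 4 (beyond the scatter). Compound 4 is estimated at 0.9, with an expected range from 0.5 to 1.3.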

Compound 4, partition coefficient: 0.9
For compound 4 middle estimate and measured number coincide at the digits printed, within the range that was stated.
By their numbers in this assay, from the lowest: compound 4; then compounds 2 and 3 (each within the scatter of the next). At a limit, above all of these: compound 1.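

In this assay, among the compounds shown here, hydrogen in place of ethyl on a saturated chain carbon, three bonds along the chain from a carbonyl carbon, gives the first fully numbered step that lies beyond the scatter: a number 0.88 log units lower from compound 3 to compound 4 (beyond the scatter). Exchanging phenyl for methyl gives a number 0.83 log units lower from compound 2 to compound 4 (beyond the scatter), whereas propyl in that place left compound 2 and compound 3 level. Hydrogen in place of butyl at the three-bond place gives a number at least 1.10 log units lower from compound 1 to compound 4 (beyond the scatter), and compound 1 stands at a limit rather than a number, so this size is only a floor: the limit of >= 2 in this assay, at which 1 of the 4 values shown sits.

The compounds shown leave open where a still shorter chain would stand. They also leave open how a chain ending in an amine or a carboxylic acid would read.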